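The compounds below may be only part of what the source reports. "The series", "measured", "known", "first", "only" and "open" are said of these compounds alone.

Measured so far in an assay on cell membranes from Cerebral cortex for displacement of a labelled ligand from Sigma non-opioid intracellular receptor 1 (Cavia porcellus), read by scintillation counting, with a stated time of 120 min; on this read-out lower numbers stand for stronger inhibition and higher numbers for weaker inhibition:

compound 1, `CN(CCCCN1CCCCC1=O)Cc1ccccc1` — > 3000 nM
compound 2, `CN(CCCCN1C(=O)CSc2ccccc21)Cc1ccccc1` — 5 nM
compound 3, `CN(CCCCN1CCCCC1=O)Cc1ccc(Cl)cc1` — 770 nM

Compound 1 gives > 3000 nM in this assay, which is a limit of the assay and not a number. Compound 2 gives 5 nM in this assay, the lowest of the two numbers shown. Compound 3 gives 770 nM in this assay.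

Compound 1 and compound 3 differ by one change, (chloro in place of hydrogen on an aromatic carbon). That change gives an at least 3.8-fold lower number from compound 1 to compound 3 (0.59 log units; beyond the scatter). The step can only be given as a bound because of the limit of > 3000 nM in this assay, at which 1 of the 3 values shown sits.

Compound 2 carries a different core from compound 1; the difference between the two cores is not broken down here. Between compound 2 and compound 3 the values stand far apart, but the two differ in core and in the substituent at once, so no single step is read from them.

Compound 4, `CN(CCCCN1C(=O)CSc2ccccc21)Cc1ccc(Cl)cc1`, is not yet measured. It differs from compound 2 by chloro in place of hydrogen on an aromatic carbon, the same change that turns compound 1 into compound 3, with the same place described for both. On the core of compound 1 this change gave an at least 3.8-fold lower number from compound 1 to compound 3 (0.59 log units; beyond the scatter). Compound 2 already sits low in this assay, so a smaller step in the same direction is expected. For compound 4 the expected step is a 2.0-fold lower number from compound 2 to compound 4 (0.30 log units; within the scatter). Compound 4 is estimated at 2.5 nM, with the expected range from 0.8 nM to 10 nM.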

Compound 4, inhibition constant: 13 nM
The estimate for compound 4 lay 5.2-fold (0.72 log units) below the measured number; the measured number lies above the stated range.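

Going from benzyl to 4-chlorobenzyl on the core of compound 2 in this assay gives a 2.6-fold higher number from compound 2 to compound 4 (0.41 log units; beyond the scatter), so the direction of this change does not carry over from the core of compound 1, as the two steps set side by side show: the same change on two cores in this assay, an at least 3.8-fold lower number (0.59 log units; beyond the scatter) from compound 1 to compound 3 and a 2.6-fold higher number (0.41 log units; beyond the scatter) from compound 2 to compound 4, at least 10-fold (1.00 log units) apart, beyond the scatter of two such steps

Compound 1 gives > 3000 nM, which is a limit of the assay and not a number, so the step on its core is known only as a bound: the limit of > 3000 nM in this assay, at which 1 of the 4 values shown sits.

With one pair of compounds on each of two cores, the notes show that the outcome of this change in the series depends on the core, but they do not show what about the cores makes the steps differ, nor how the change would read on a third core.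

Still open, as far as these compounds go, is whether the same split between the two cores appears with another group at that place on the aromatic ring, such as fluoro, methyl or methoxy. Also open, from the compounds shown here alone, is whether it persists with a longer chain linking the amine to each core, or with an ethyl group in place of the methyl on that amine.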